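Swapping Methanesulfonamido for Dimethylcarbamoyl on the Benzyl Ring

A few compounds are considered here, and "the series" means these few. Any claim that something is new, unique, unknown or untested is made for them only; others in the source may bear on it.

Compound 2 `CC(C)(C)c1ccc(C(=O)NCc2ccc(NS(C)(=O)=O)cc2)cc1` and compound 1 `CC(C)(C)c1ccc(C(=O)NCc2ccc(C(=O)O)cc2F)cc1` share a core and differ in the group carried on one aromatic ring. In an assay on HeLa cells with Bile acid receptor (Homo sapiens) as the target, read by a luciferase reporter, with a stated time of 24 h (on this read-out higher numbers stand for an effect only at larger amounts of compound and lower numbers for an effect already at smaller amounts), compound 1 gives 7.8 nM, while compound 2 gives 44 nM, the higher of the two numbers and beyond the scatter from compound 1. Compound 3 `CN(C)C(=O)c1ccc(CNC(=O)c2ccc(C(C)(C)C)cc2)cc1` arises from compound 2 by the change (dimethylcarbamoyl in place of methanesulfonamido on an aromatic carbon). Among the compounds with values here, no measured pair shows this kind of change, so the expectation is loose. In this assay compound 3 is expected to give 80 nM, between 20 nM and 320 nM. The estimated step of a 1.8-fold higher number from compound 2 to compound 3 (0.26 log units; within the scatter) is expected to be small, possibly none beyond the scatter.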

Compound 3, half-maximal effective concentration: 170 nM
Estimate against measurement, compound 3: 2.1-fold (0.33 log units) below; the measured number falls inside the stated range.
By their numbers in this assay, from the lowest: compound 1; then compound 2; then compound 3.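

In this assay, within the data shown here, replacing methanesulfonamido with dimethylcarbamoyl on an aromatic carbon para to a large group gives a 3.9-fold higher number from compound 2 to compound 3 (0.59 log units; beyond the scatter) and so provides the first direct evidence that the group at this position affects the read-out. The exchange keeps the heavy-atom count the same but removes the hydrogen-bond donor, although this alone does not identify what drives the step. No supporting data are available to explain the difference. The compounds shown leave open how an amine or an unsubstituted carbamoyl would read at this position on the same core.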